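The source may hold more compounds than are shown below. What is called first, only, known or untested is meant among the compounds shown, and "the series" means these compounds.

Measured in an ADME assay on HeLa cells (Homo sapiens) for cytotoxicity; a higher number here means that more compound is tolerated, a lower number that less compound is tolerated:

Compound 1 `COc1ccc(-c2c(C)nc3c(N)cc(Cl)nn23)cc1OC` gives > 1750 nM
Compound 2 `COc1ccc(-c2c(C)nn3c(NCCNC(=O)C(C)C)cc(C)nc23)cc1OC` gives > 50000 nM
Compound 3 `CC(=O)NCCNc1cc(Cl)nn2c(-c3cccc(S(=O)(=O)NC(C)C)c3)c(C)nc12` gives > 50000 nM

All three entries are limits rather than numbers. Compound 1 stands at > 1750 nM, which is a limit of the assay. The account now follows compound 4 `COc1ccc(-c2c(C)nc3c(NCCNC(C)=O)cc(Cl)nn23)cc1OC`, which has not yet been measured. It departs from compound 1 by one change, (2-acetamidoethyl in place of hydrogen on a nitrogen on an aromatic ring), with 2-acetamidoethyl in place of hydrogen on a nitrogen on an aromatic ring.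

Going by the values given here, no measured pair in this assay shows the size of such a step, so any expectation is tentative. Compound 2 stands at > 50000 nM, also a limit. Compound 3 stands at > 50000 nM, again a limit. On the strength of these two compounds, compound 4 is expected to be well tolerated as well, and it may well return only a limit. The expected move is upward, an estimated step that the limit leaves unreadable from compound 1 to compound 4, although its true size is uncertain since it starts from a limit. For compound 4 the estimated value is 50000 nM, with an expected range from 20000 nM to 100000 nM.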

Compound 4, half-maximal cytotoxic concentration: > 50000 nM
Compound 4: only a limit was reported; the forecaster's own chance of this, stated with the estimate: 85%; the middle value sits exactly at the limit.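

Compound 1 and compound 4 both return only limits in this assay, and the step between them cannot be read. The compounds shown leave open at what concentration any of them becomes cytotoxic, and whether 2-acetamidoethyl in place of hydrogen changes tolerance at all.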